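Taking the fluoro off compound 3

This account rests on a few compounds, and the source may have more. Where it says the series, first, only, none or still open, it means among the compounds named here.

compound 1 `COc1ccc(S(=O)(=O)N2CCc3cccc(-c4ccc(N(C)C)cc4)c32)cc1`: 539 nM
compound 2 `COc1ccc(S(=O)(=O)N2CCc3cccc(-c4ccc(F)cc4)c32)cc1`: 86 nM
compound 3 `COc1ccc(S(=O)(=O)N2CCc3cccc(-c4cccc(F)c4)c32)cc1`: 98.5 nM
compound 4 `COc1ccc(S(=O)(=O)N2CCc3cccc(-c4ccccc4)c32)cc1`: not yet measured

In a functional assay on KB cells (Homo sapiens) for inhibition, with a stated time of 72 h (on this read-out lower numbers stand for stronger inhibition and higher numbers for weaker inhibition), compound 3 gives 98.5 nM, which places it together with compound 2 and well apart from compound 1. The step of a 1.1-fold higher number from compound 2 to compound 3 (0.06 log units; within the scatter) lies within the scatter, so the two fluoro compounds cannot be told apart here. The steps of a 6.3-fold lower number from compound 1 to compound 2 (0.80 log units; beyond the scatter) and a 5.5-fold lower number from compound 1 to compound 3 (0.74 log units; beyond the scatter) are both beyond the scatter.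

Compound 4 differs from compound 3 by one small edit: hydrogen in place of fluoro on an aromatic carbon. That is hydrogen in place of fluoro on an aromatic carbon, meta to a large group. For the measured compounds named here, no measured pair shows this exact swap, so the evidence is indirect. The closest guide is a 1.1-fold higher number from compound 2 to compound 3 (0.06 log units; within the scatter), a change that also involves only the fluoro and leaves the number within the scatter. Going by the values given here, the larger steps from compound 1 involve the loss of dimethylamino, which has no counterpart in this edit. In this assay, then, no step beyond the scatter is expected. The expected size of the change is a 1.1-fold higher number from compound 3 to compound 4 (0.03 log units; within the scatter). For compound 4 the estimated value is 105 nM, with an expected range of 50 nM to 220 nM.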

Compound 4, half-maximal inhibitory concentration: 120 nM
Compound 4: middle estimate off by 1.1-fold (0.06 log units), on the low side, within the range that was stated.
By their numbers in this assay, from the lowest: compounds 2, 3 and 4 (each within the scatter of the next); then compound 1.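

For the compounds shown here, compound 4 carries a plain phenyl, so in this assay it gives the first direct reading of what a fluoro on this ring contributes. Hydrogen in place of fluoro gives a 1.2-fold higher number from compound 3 to compound 4 (0.09 log units; within the scatter) and, starting from the other fluoro compound, a 1.4-fold higher number from compound 2 to compound 4 (0.14 log units; within the scatter) and so neither swap can be told apart from repeat measurement. The earlier compounds shown here could only set the two fluoro compounds against each other, whereas these steps show that a number in this range does not depend on having a fluoro on the ring at all, and a 4.5-fold lower number from compound 1 to compound 4 (0.65 log units; beyond the scatter) shows that compound 1 stands apart from the plain phenyl too, which ties the gap to the presence of its dimethylamino group rather than to the absence of fluoro.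

From the compounds shown here alone, it remains open whether other groups at this place on the ring, such as a nitrile, a primary amine or a carboxylic acid, would stay level with compound 4 or move towards compound 1. Nothing given here explains why fluoro and hydrogen read alike or why the dimethylamino compound differs.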